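Furan for Chlorophenyl on the Shared Core: What to Expect

The source may hold more compounds than are shown below. What is called first, only, known or untested is meant among the compounds shown, and "the series" means these compounds.

Compound 1, `CCCSc1nc(N/N=C(\C)c2ccccc2O)c2nnn(Cc3ccc(Cl)cc3)c2n1`: 42600 nM
Compound 2, `C#CCSc1nc(N/N=C(\C)c2ccccc2O)c2nnn(Cc3ccccc3)c2n1`: 11300 nM

Both numbers come from a functional assay on MCF7 cells (Homo sapiens) for antiproliferative activity, read by MTT assay, with a stated time of 72 h; a higher number here means a weaker inhibitor, a lower number a stronger inhibitor. Compound 1 gives 42600 nM and stands with the higher of the two numbers; compound 2 gives 11300 nM, a lower number by a margin beyond the scatter. The two compounds differ in more than one place, so no single step can be read between them.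

Compound 3, `CCCSc1nc(N/N=C(\C)c2ccccc2O)c2nnn(Cc3ccco3)c2n1`, has not yet been measured. It differs from compound 1 by furan-2-yl in place of 4-chlorophenyl on a saturated chain carbon bound to an aromatic nitrogen. Within the data shown here, no measured step of this kind exists among the compounds here, so the expectation rests on compound 1 alone. Compound 3 is expected to land close to its parent, a step of a 1.2-fold lower number from compound 1 to compound 3 (0.09 log units; within the scatter) that is not expected to reach beyond the scatter in either direction. The estimate for compound 3 in this assay is 35000 nM, within a range from 10000 nM to 120000 nM.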

Compound 3, half-maximal inhibitory concentration: 29000 nM
Estimate against measurement, compound 3: 1.2-fold (0.08 log units) above; the measured number falls inside the stated range.
By their numbers in this assay, from the lowest: compound 2; then compounds 3 and 1 (each within the scatter of the next).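

In this assay, among these compounds, the first step that can be read on the shared core is a 1.5-fold lower number from compound 1 to compound 3 (0.17 log units; within the scatter) and so leaves furan-2-yl and 4-chlorophenyl indistinguishable at this position, on a saturated chain carbon bound to an aromatic nitrogen. In this one pair, a five-membered aromatic ring with 1 hetero atom stands in for a six-membered aromatic ring of carbon only, with fewer heavy atoms and a hydrogen-bond acceptor added, and the step stays within the scatter. No measurement of any property of these groups bears on this result.

Compound 2 differs from compound 1 and compound 3 in more than one place, so the steps to it cannot be read. Going by these compounds, whether a pyridine ring, an aliphatic amine or a carboxylic acid in place of furan-2-yl would move the number beyond the scatter remains open.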